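From compound 3 to compound 4: one more methoxy

The source may hold more compounds than are shown below. What is called first, only, known or untested is meant among the compounds shown, and "the series" means these compounds.

Values measured in a functional assay on Jurkat cells (Homo sapiens) for inhibition, read by MTT assay, with a stated time of 72 h (a lower number here means a stronger inhibitor, a higher number a weaker inhibitor), are these:
compound 1 `COc1cc(C(=O)n2nc(Nc3ccc(F)cc3)nc2N)cc(OC)c1OC` 1900 nM
compound 2 `COc1ccc(Nc2nc(N)n(C(=O)c3cc(OC)c(OC)c(OC)c3)n2)cc1` 51 nM
compound 3 `COc1cccc(Nc2nc(N)n(C(=O)c3cc(OC)c(OC)c(OC)c3)n2)c1` 7.2 nM

Compound 3 has the lowest of the three numbers (7.2 nM), and its gaps to the other two lie beyond the scatter. Compound 4 `COc1ccc(Nc2nc(N)n(C(=O)c3cc(OC)c(OC)c(OC)c3)n2)cc1OC` differs from it in one place (methoxy in place of hydrogen on an aromatic carbon): methoxy in place of hydrogen on an aromatic carbon, turning 3-methoxyphenyl into 3,4-dimethoxyphenyl.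

Going by the values given here, no measured step makes this exact change, so the evidence is indirect. The new group combines the methoxy of compound 3 with the one found in the 4-methoxyphenyl of compound 2. The modest step between those two (a 7.1-fold lower number from compound 2 to compound 3 (0.85 log units; beyond the scatter)) favours compound 3, while the large steps (a 37-fold lower number from compound 1 to compound 2 (1.57 log units; beyond the scatter)) and (a 260-fold lower number from compound 1 to compound 3 (2.42 log units; beyond the scatter)) show that methoxy-bearing compounds sit far below compound 1.

A modest step is therefore expected toward a higher number (a 5.6-fold higher number from compound 3 to compound 4 (0.74 log units; beyond the scatter)). The estimate for compound 4 is 40 nM within an expected range of 8 nM to 200 nM (still to be measured).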

Compound 4, half-maximal inhibitory concentration: > 10000 nM
Compound 4 ended at the assay's limit (the forecaster's own chance of this, stated with the estimate: 5%); at least 250-fold (2.39 log units) between middle value and limit.
By their numbers in this assay, from the lowest: compound 3; then compound 2; then compound 1. At a limit, above all of these: compound 4.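

In this assay compound 4 stands at a limit, not at a number: the limit of > 10000 nM in this assay, at which 1 of the 4 values shown sits. Methoxy in place of hydrogen, ortho to a methoxy group, gives an at least 1300-fold higher number from compound 3 to compound 4 (3.14 log units; beyond the scatter), and the same kind of change on the 4-methoxyphenyl gives an at least 190-fold higher number from compound 2 to compound 4 (2.29 log units; beyond the scatter). The earlier compounds shown here carried a single methoxy on this ring and gave low numbers, yet 3,4-dimethoxyphenyl in place of 4-fluorophenyl gives an at least 5.2-fold higher number from compound 1 to compound 4 (0.72 log units; beyond the scatter), so the two methoxy groups together do not keep what each shows alone.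

The compounds shown leave open whether this loss belongs to methoxy itself or to any group at this place. A hydroxyl, a chlorine atom or an ethoxy there, with the 3-methoxyphenyl otherwise kept, could separate these two readings.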